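Replacing 4-Chloro-3-methylphenyl with 5-Chloropyridin-2-yl

The compounds below may be only part of what the source reports. "The series", "measured", "known", "first", "only" and "open" are said of these compounds alone.

In an in vitro ADME assay on microsomes from liver (Homo sapiens) for pharmacokinetics, read by LC-MS, with a stated time of 10 min, tested at 1 uM (on this read-out higher numbers stand for fast clearance and lower numbers for slow clearance), compound 1 `CN1C[C@H](C(=O)Nc2ccc(F)c(Cl)c2)[C@@H](c2ccc(/C=C/C(=O)Nc3ccccc3N)cc2)C1` gives 15 mL/min/kg, compound 2 `CN1C[C@H](C(=O)Nc2ccc(Cl)c(Cl)c2)[C@@H](c2ccc(/C=C/C(=O)Nc3ccccc3N)cc2)C1` gives 14 mL/min/kg and compound 3 `Cc1cc(NC(=O)[C@H]2CN(C)C[C@@H]2c2ccc(/C=C/C(=O)Nc3ccccc3N)cc2)ccc1Cl` gives 15 mL/min/kg. Compound 3 is level with compound 1 at the digits shown, and all three numbers lie within the scatter of one another.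

Compound 4 `CN1C[C@H](C(=O)Nc2ccc(Cl)cn2)[C@@H](c2ccc(/C=C/C(=O)Nc3ccccc3N)cc2)C1` has 5-chloropyridin-2-yl in place of 4-chloro-3-methylphenyl on an amide-type nitrogen. Within the data shown here, the closest precedent is the exchange of one aromatic group for another at this same place, no change at the digits printed from compound 1 to compound 3 (within the scatter). The smaller substituent exchanges give a 1.1-fold lower number from compound 1 to compound 2 (0.03 log units; within the scatter) and a 1.1-fold higher number from compound 2 to compound 3 (0.03 log units; within the scatter). All three steps are within the scatter, but none of them puts a hetero atom into the aromatic ring, so the data give no direct guide to this feature. No shift beyond the scatter is therefore expected, and the direction remains uncertain. The expected step is a 1.2-fold lower number from compound 3 to compound 4 (0.06 log units; within the scatter). Compound 4 is estimated at 13 mL/min/kg, with an expected range of 8 mL/min/kg to 21 mL/min/kg.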

Compound 4, clearance: 13 mL/min/kg
For compound 4 middle estimate and measured number coincide at the digits printed; the measured number falls inside the stated range.
By their numbers in this assay, from the lowest: compounds 4, 2, 1 and 3 (each within the scatter of the next).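

In this assay, among these compounds, a ring with a hetero atom on the amide-type nitrogen, a feature absent from the earlier compounds, stays level with the carbon-only rings: the steps are a 1.2-fold lower number from compound 3 to compound 4 (0.06 log units; within the scatter) and a 1.1-fold lower number from compound 2 to compound 4 (0.03 log units; within the scatter) and also a 1.2-fold lower number from compound 1 to compound 4 (0.06 log units; within the scatter) on this read-out. At this position, then, 5-chloropyridin-2-yl matches 4-chloro-3-methylphenyl, 3,4-dichlorophenyl and 3-chloro-4-fluorophenyl within the scatter, and the ring nitrogen brings no measurable shift in these compounds. Nothing available here accounts for this result.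

All four aromatic groups carry chlorine, so the compounds shown leave open how an unsubstituted phenyl or a pyrimidinyl ring would behave at this place. They also leave open whether an amine or a carboxylic acid on the ring would move the number beyond the scatter.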